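A few compounds are considered here, and "the series" means these few. Any claim that something is new, unique, unknown or untested is made for them only; others in the source may bear on it.

Of the compounds shown here, two built on a shared core have so far been measured in a functional assay on HT-29 cells (Homo sapiens) for antiproliferative activity, read by MTT assay, with a stated time of 72 h; a lower number here means a stronger inhibitor, a higher number a weaker inhibitor. Compound 1 `CN(C)CCn1cnnc1-c1cc(Oc2ccc(NC(=O)Nc3ccc(F)c(F)c3)cc2F)ccn1` gives 3620 nM in this assay, the highest of the two numbers. Compound 2 `CN(C)CCn1cnnc1-c1cc(Oc2ccc(NC(=O)Nc3ccc(F)c(Cl)c3)cc2F)ccn1` gives 720 nM in this assay. For the measured compounds named here, the only step between measured compounds, a 5.0-fold lower number from compound 1 to compound 2 (0.70 log units; beyond the scatter), exchanges one halogen for another on an aromatic carbon and says nothing about the chain that carries the dimethylamino group.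

Compound 3 `CN(C)CCCn1cnnc1-c1cc(Oc2ccc(NC(=O)Nc3ccc(F)c(F)c3)cc2F)ccn1` differs from compound 1 by (dimethylamino)methyl in place of dimethylamino on a saturated chain carbon, two bonds along the chain from an aromatic nitrogen; read from further out, 2-(dimethylamino)ethyl becomes 3-(dimethylamino)propyl. Going by the values given here, no measured step touches this chain, so the data give no ground to expect a change beyond the scatter in this assay in either direction. Compound 3 is therefore expected to give about 3600 nM in this assay, with a range from 1500 nM to 9000 nM. Among the compounds with values here, the step this estimate means, a 1.0-fold lower number from compound 1 to compound 3 (0.00 log units; within the scatter), is expected to stay within the scatter of repeated measurements, and a result outside that range would be the first information on this chain.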

Compound 3, half-maximal inhibitory concentration: 1210 nM
For compound 3 the middle estimate is 3.0-fold (0.47 log units) above the measured one; the measured number lies below the stated range.
By their numbers in this assay, from the lowest: compounds 2 and 3 (each within the scatter of the next); then compound 1.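

Adding one carbon to the chain on the aromatic nitrogen, so that 2-(dimethylamino)ethyl becomes 3-(dimethylamino)propyl, gives a 3.0-fold lower number from compound 1 to compound 3 (0.48 log units; beyond the scatter) in this assay and shows that this chain is not a silent part of the molecule. The chain is thus a second place, after the halogen on the aromatic ring, where a single change to compound 1 moves the number beyond the scatter, although this rests on one step from one starting compound. No available measurement explains why the longer chain goes with the lower number, so the result remains an observation without a known cause.

From the compounds shown here alone, it remains open whether the same lengthening would lower the number for compound 2, which carries the chloro group, and whether a still longer chain such as 4-(dimethylamino)butyl would continue the trend or reverse it. The role of the group at the end of the chain is also unsettled, and a primary amine, a morpholine ring or a pyrrolidine ring in place of dimethylamino would begin to test it.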